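This account rests on a few compounds, and the source may have more. Where it says the series, first, only, none or still open, it means among the compounds named here.

Measured compounds: compound 1 `COc1cc2c(Nc3nc4ccc(C(=O)Nc5c(C)cccc5Cl)cc4s3)ncnc2cc1OCCCN1CCC(C)CC1`, 11300 nM; compound 2 `CCN(CC)CCCOc1cc2ncnc(Nc3nc4ccc(C(=O)Nc5c(C)cccc5Cl)cc4s3)c2cc1OC`, 11700 nM; compound 3 `COc1cc2c(Nc3nc4ccc(C(=O)Nc5c(C)cc(C)cc5C)cc4s3)ncnc2cc1OCCCN1CCCCC1`, 24500 nM.

Compound 3 stands highest of the three numbers in a functional assay on DLD-1 cells (Homo sapiens) for cytotoxicity, read by WST assay, with a stated time of 72 h (a higher number here means a weaker inhibitor, a lower number a stronger inhibitor), beyond the scatter from compound 2 and from compound 1. Compound 4 `COc1cc2c(Nc3nc4ccc(C(=O)Nc5c(C)cccc5Cl)cc4s3)ncnc2cc1OCCCN1CCCCC1` differs from compound 3 in one place: 2-chloro-6-methylphenyl in place of 2,4,6-trimethylphenyl on an amide-type nitrogen. Among the measured compounds shown here, no measured pair changes this amide substituent, so no step bears on it directly; the only measured step, a 1.0-fold higher number from compound 1 to compound 2 (0.02 log units; within the scatter), concerns the amine end of the chain. Compounds 1 and 2 both carry the group that enters and both sit near the same value, while compound 3 carries the group that leaves. A step downward is therefore expected, estimated as a 2.1-fold lower number from compound 3 to compound 4 (0.33 log units; beyond the scatter). Compound 4 is expected at 11500 nM, with a range of 6000 nM to 22000 nM.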

Compound 4, half-maximal inhibitory concentration: 14700 nM
Estimate against measurement, compound 4: 1.3-fold (0.11 log units) below; low and high end bracket the measured number.
By their numbers in this assay, from the lowest: compounds 1, 2, 4 and 3 (each within the scatter of the next, the first and the last beyond it).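

In this assay the change on the amide-type nitrogen, 2-chloro-6-methylphenyl in place of 2,4,6-trimethylphenyl, gives a 1.7-fold lower number from compound 3 to compound 4 (0.22 log units; within the scatter) and so stays within the scatter as a single step. With 2-chloro-6-methylphenyl in place, piperidin-1-yl instead of diethylamino gives a 1.3-fold higher number from compound 2 to compound 4 (0.10 log units; within the scatter) and hydrogen instead of methyl on a saturated ring carbon gives a 1.3-fold higher number from compound 1 to compound 4 (0.11 log units; within the scatter), so these three amine ends read alike. Nothing at hand gives a cause for these numbers. Going by these compounds, it stays open whether an unsubstituted phenyl on the amide-type nitrogen, or a morpholine or a carboxylic acid at the chain end, would give a step beyond the scatter.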